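Inverting one ring stereocentre in a benzodioxane antagonist

This account rests on a few compounds, and the source may have more. Where it says the series, first, only, none or still open, it means among the compounds named here.

Of the compounds shown here, three sharing one core have been measured in a functional assay for antagonist activity at Adrenergic receptor alpha-1 (Rattus norvegicus); a lower number here means tighter binding, a higher number weaker binding. Compound 1 `COc1cccc(OC)c1OCCNC[C@H]1Oc2ccccc2O[C@@H]1C1CCCCC1` gives 813 nM, compound 2 `COc1cccc(OC)c1OCCNC[C@H]1Oc2ccccc2O[C@@H]1c1ccc(Cl)cc1` gives 7.08 nM, and compound 3 `CCc1ccc([C@@H]2Oc3ccccc3O[C@@H]2CNCCOc2c(OC)cccc2OC)cc1` gives 58.9 nM. Compound 3 therefore stands second highest of the three: its number lies beyond the scatter from that of compound 2, which is lower, and beyond the scatter from that of compound 1, which is higher. Among the measured compounds shown here, the one single-point step measured, a 110-fold lower number from compound 1 to compound 2 (2.06 log units; beyond the scatter), was large.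

Compound 4 `CCc1ccc([C@H]2Oc3ccccc3O[C@@H]2CNCCOc2c(OC)cccc2OC)cc1` is the next step from compound 3: the two compounds have the same atoms and bonds and differ only in configuration as drawn: 1 of 2 stereo elements differ; a stereocentre at a saturated ring carbon is drawn S in compound 3 and R in compound 4. For the measured compounds named here, no measured step touches configuration; the step from compound 1 to compound 2 concerns a change of group, not of stereochemistry, so it gives no guide to size or direction here. From the compounds shown here alone, with all three measured compounds drawn in the same configuration, the effect of this inversion is unknown, and a change in either direction is possible. The expected outcome for compound 4 in this assay is a somewhat higher number, a 2.5-fold higher number from compound 3 to compound 4 (0.41 log units; beyond the scatter), given as 150 nM with a range from 20 nM to 1500 nM.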

Compound 4, dissociation constant: 15.1 nM
Compound 4: middle estimate off by 9.9-fold (1.00 log units), on the high side, outside the stated range (below it).
By their numbers in this assay, from the lowest: compound 2; then compound 4; then compound 3; then compound 1.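

In this assay the configuration at this saturated ring carbon counts on its own, with a 3.9-fold lower number from compound 3 to compound 4 (0.59 log units; beyond the scatter), and this modest gap belongs to the inversion alone: the fact that compounds 3 and 4 differ only in the configuration as drawn. With the 4-ethylphenyl group in the configuration of compound 4, the distance to the 4-chlorophenyl compound shrinks to a 2.1-fold higher number from compound 2 to compound 4 (0.33 log units; beyond the scatter), still modest and still beyond the scatter. The earlier contrast with cyclohexyl also holds for this second aromatic group, with a 54-fold lower number from compound 1 to compound 4 (1.73 log units; beyond the scatter), a large step like a 110-fold lower number from compound 1 to compound 2 (2.06 log units; beyond the scatter).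

From the compounds shown here alone, what the same inversion would do with 4-chlorophenyl or cyclohexyl on this carbon remains open, in both size and direction. Also open, going by these compounds, is how a methoxy group or an amine in place of the ethyl would fare in this configuration.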